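This account rests on a few compounds, and the source may have more. Where it says the series, first, only, none or still open, it means among the compounds named here.

Three compounds share one core and differ only in the group on the saturated chain carbon bound to an aromatic nitrogen. In a functional assay (B cells) with Mus musculus as the target (a higher number here means that more compound is needed for the effect, a lower number that less compound is needed), compound 1 `Nc1nc(O)c2c(n1)n(C1OC(CO)[C@@H](O)[C@H]1O)c(=O)n2Cc1ccc(Cl)cc1` gives 14 uM; compound 2 `Nc1nc(O)c2c(n1)n(C1OC(CO)[C@@H](O)[C@H]1O)c(=O)n2Cc1ccccc1` gives 6 uM; compound 3 `Nc1nc(O)c2c(n1)n(C1OC(CO)[C@@H](O)[C@H]1O)c(=O)n2Cc1ccc(OCc2ccccc2)cc1` gives 8 uM. Compound 2 has the lowest of the three numbers: its nearest neighbour is compound 3, with a 1.3-fold higher number from compound 2 to compound 3 (0.12 log units; within the scatter), and its furthest is compound 1, the step of a 2.3-fold lower number from compound 1 to compound 2 (0.37 log units; beyond the scatter) lying beyond the scatter. Compound 4 `Nc1nc(O)c2c(n1)n(C1OC(CO)[C@@H](O)[C@H]1O)c(=O)n2C/C=C/c1ccccc1` has not yet been measured. It differs from compound 2 as follows: 2-phenylethenyl in place of phenyl on a saturated chain carbon bound to an aromatic nitrogen. Among the measured compounds shown here, no measured step touches this part of the molecule; the steps of a 2.3-fold lower number from compound 1 to compound 2 (0.37 log units; beyond the scatter), a 1.8-fold lower number from compound 1 to compound 3 (0.24 log units; within the scatter) and a 1.3-fold higher number from compound 2 to compound 3 (0.12 log units; within the scatter) all concern substituents on the aromatic ring and are modest or within the scatter. The chemist therefore expects the number for compound 4 to sit close to the others, the expected step being a 1.3-fold higher number from compound 2 to compound 4 (0.12 log units; within the scatter), with no change beyond the scatter. The estimate for compound 4 in this assay is 8 uM, in the range 3 uM to 20 uM.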

Compound 4, concentration for half-maximal effect: 103 uM
For compound 4 the middle estimate is 13-fold (1.11 log units) below the measured one; the whole stated range lies below it.
By their numbers in this assay, from the lowest: compounds 2, 3 and 1 (each within the scatter of the next, the first and the last beyond it); then compound 4.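

In this assay, among the compounds shown here, changing benzyl to 3-phenylprop-2-en-1-yl on the aromatic nitrogen gives a large step (a 17-fold higher number from compound 2 to compound 4 (1.23 log units; beyond the scatter)), whereas the substituents on the aromatic ring in the earlier compounds produced only modest steps or steps within the scatter. The step from the chlorinated compound is also beyond the scatter (a 7.4-fold higher number from compound 1 to compound 4 (0.87 log units; beyond the scatter)), so compound 4 stands apart from all three earlier compounds, and this position responds more strongly to the change in the chain than the ring did to any of its substituents, including the benzyloxy group of compound 3. Nothing available explains this step.

The compounds shown leave open whether the longer chain or its double bond accounts for the step, a question that a saturated 3-phenylpropyl group could separate. They also leave open how an amine or a carboxylic acid at this position would read in this assay.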